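The compounds below may be only part of what the source reports. "The series", "measured", "known", "first", "only" and "open" are said of these compounds alone.

In a functional assay on A549 cells (Homo sapiens) for cytotoxicity, read by MTT assay, with a stated time of 72 h (a higher number here means a weaker inhibitor, a lower number a stronger inhibitor), compound 1 `CNC(=O)c1cc(Oc2ccc(NC(=O)c3cc(-c4ccc(Cl)cc4)ncn3)cc2F)ccn1` gives only a limit, > 100000 nM, and not a number. Compound 2 `CNC(=O)c1cc(Oc2ccc(NC(=O)c3cc(-c4ccc(Cl)cc4)ncn3)cc2)ccn1` also gives only a limit, > 100000 nM, so hydrogen in place of fluoro yields a step that the two limits leave unreadable from compound 1 to compound 2. With hydrogen in place of chloro, compound 3 `CNC(=O)c1cc(Oc2ccc(NC(=O)c3cc(-c4ccccc4)ncn3)cc2)ccn1` gives a measured 27100 nM. This is an at least 3.6-fold lower number from compound 2 to compound 3 (0.56 log units; beyond the scatter).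

Compound 4 `CNC(=O)c1cc(Oc2ccc(NC(=O)c3cc(-c4ccc(F)cc4)ncn3)cc2F)ccn1` keeps the fluoro of compound 1 but has 4-fluorophenyl instead of 4-chlorophenyl: fluoro in place of chloro on an aromatic carbon. The chloro step to compound 3 is the nearest guide, though here fluoro, not hydrogen, replaces chloro. Part of that drop is therefore expected, with the number moving lower: the expected change is an at least 1.8-fold lower number from compound 1 to compound 4 (0.25 log units; that floor lies within the scatter). For compound 4, the estimated value is 55000 nM, within a range of 20000 nM to 100000 nM.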

Compound 4, half-maximal inhibitory concentration: > 100000 nM
Compound 4: only a limit was reported; the forecaster's own chance of this, stated with the estimate: 35%; at least 1.8-fold (0.25 log units) between middle value and limit.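

Compound 1 and compound 4 both stand only as limits, so no step between them can be read: the limit of > 100000 nM in this assay, at which 3 of the 4 values shown sit.

From the compounds shown here alone, whether fluoro in place of chloro changes the number in this assay stays open for this pair.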